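Adding a Methyl Beside an Imidazole Core

A few compounds are considered here, and "the series" means these few. Any claim that something is new, unique, unknown or untested is made for them only; others in the source may bear on it.

Of the compounds shown here, three have been measured in an ADME assay on MDCK cells (Canis lupus familiaris) for cytotoxicity, read by MTT assay, with a stated time of 48 h; a lower number here means that less compound is tolerated, a higher number that more compound is tolerated. Compound 1, `CCc1nc[nH]c1CN[C@@H]1C[C@@H]2C[C@H]([C@H]1C)C2(C)C`, gives 180000 nM in this assay. Compound 2, `CCCc1nc[nH]c1CN[C@@H]1C[C@@H]2C[C@H]([C@H]1C)C2(C)C`, gives 200000 nM. Compound 3, `Cc1ncc(CN[C@@H]2C[C@@H]3C[C@H]([C@H]2C)C3(C)C)[nH]1`, gives 202000 nM. All three numbers lie within the usual scatter of one another, so no order among them can be claimed.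

The change from compound 1 to compound 2 is methyl in place of hydrogen on a saturated chain carbon, two bonds along the chain from an aromatic carbon and it produced a 1.1-fold higher number from compound 1 to compound 2 (0.05 log units; within the scatter) in this assay.

Compound 4, `CCc1ncc(CN[C@@H]2C[C@@H]3C[C@H]([C@H]2C)C3(C)C)[nH]1`, has not yet been measured. It differs from compound 3 by methyl in place of hydrogen on a saturated chain carbon bound to an aromatic carbon. The difference between the core of compound 3 and the core of compound 1 is not broken down here. The change from compound 3 to compound 4 is the same kind of change as that from compound 1 to compound 2, yet not the same: in the earlier pair the methyl enters on a saturated chain carbon two bonds along the chain from an aromatic carbon, whereas here it enters on a saturated chain carbon bound to an aromatic carbon.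

Because a 1.1-fold higher number from compound 1 to compound 2 (0.05 log units; within the scatter) was within the scatter, the step of a 1.0-fold higher number from compound 3 to compound 4 (0.02 log units; within the scatter) is expected to be small as well. Compound 4 is therefore estimated at 210000 nM, with a likely range from 120000 nM to 360000 nM.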

Compound 4, half-maximal cytotoxic concentration: 137000 nM
Beside the measured number, compound 4's estimate is 1.5-fold (0.19 log units) above it; low and high end bracket the measured number.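

In this assay, the new step is a 1.5-fold lower number from compound 3 to compound 4 (0.17 log units; within the scatter), so the added methyl gives no change that can be told from the usual scatter of repeated measurements. Set beside the earlier step, the change carries from one core to the other with no difference that can be claimed: the same change on two cores in this assay, a 1.1-fold higher number (0.05 log units; within the scatter) from compound 1 to compound 2 and a 1.5-fold lower number (0.17 log units; within the scatter) from compound 3 to compound 4, 1.6-fold (0.21 log units) apart, within the scatter of two such steps. Within the data shown here, this does not show that the change acts alike on every core: only two pairs are at hand, the methyl enters a different place in each, on a saturated chain carbon bound to an aromatic carbon in one and two bonds along the chain from an aromatic carbon in the other, and neither step stands beyond the scatter.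

The compounds shown leave open whether any group at this place would move the number beyond the scatter. A carboxylic acid or an amine on the chain, or a longer chain on the core of compound 3, would be needed to answer that.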